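Chloro on the pendant phenyl of an inactive benzoxazinone

The source may report more compounds than this note shows. Statements on the series, on what has been measured and on what is new or still open speak of the compounds shown alone.

Measured compounds, with their values in a functional assay on MCF7 cells (Homo sapiens) for antiproliferative activity, read by MTT assay, with a stated time of 72 h; a higher number here means a weaker inhibitor, a lower number a stronger inhibitor:
- compound 1, `Cc1ccc(N2C(=O)COc3ccc(-c4cnc5ccccc5c4)cc32)cc1`: compound 1 gives > 40000 nM, a limit of the assay.
- compound 2, `COc1ccc(N2C(=O)COc3ccc(-c4cnc(OC)c(NS(=O)(=O)c5ccc(F)cc5)c4)cc32)cc1`: compound 2 gives 8260 nM.
- compound 3, `O=C1COc2ccc(-c3cnc(Cl)c(NS(=O)(=O)c4ccc(F)cc4)c3)cc2N1c1ccccc1`: compound 3 gives > 40000 nM, a limit of the assay.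

Compound 3 stands at the edge of what this assay reports: its value is only a limit, and it shares that position with compound 1, as the limit of > 40000 nM in this assay, at which 2 of the 3 values shown sit, shows. Compound 2 is the only one of the three with a measured number, and even that number is weak.

Compound 4, `O=C1COc2ccc(-c3cnc(Cl)c(NS(=O)(=O)c4ccc(F)cc4)c3)cc2N1c1ccc(Cl)cc1`, differs from compound 3 in one place: chloro in place of hydrogen on an aromatic carbon. Cut one bond further out, the change reads phenyl to 4-chlorophenyl. Among the measured compounds shown here, no measured pair shows what such a change does here, so the expectation rests on the limit alone. The step from compound 3 to compound 4 is expected to be a number no higher from compound 3 to compound 4 (the limit leaves the size open), that is, nothing beyond the scatter. Compound 4 is therefore estimated at 40000 nM, in a range from 15000 nM to 100000 nM, most likely again reported only as a limit.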

Compound 4, half-maximal inhibitory concentration: 32800 nM
Compound 4: middle estimate off by 1.2-fold (0.09 log units), on the high side, and the stated range covers the measured number.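

With chloro in place of hydrogen para to the large group on the pendant phenyl, the series gains a measured number in this assay: compound 4 gives 32800 nM. Compound 3 remains a limit of the assay at > 40000 nM. The step reads an at least 1.2-fold lower number from compound 3 to compound 4 (0.08 log units; that floor lies within the scatter), so it shows only a floor that does not clear the scatter, and its true size stays unknown, with the limit still the main feature of this small set: the limit of > 40000 nM in this assay, at which 2 of the 4 values shown sit.

The compounds shown leave open what an amine or a carboxylic acid at that same position of the pendant phenyl would do. They also leave open whether chloro there would change the number for a compound whose partner is measured rather than a limit.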